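Fluoro for Chloro on the Benzyl Ring of a Triazole Dithiocarbamate

The source may hold more compounds than are shown below. What is called first, only, known or untested is meant among the compounds shown, and "the series" means these compounds.

Two compounds share a core in which a piperazine dithiocarbamate is joined through a thioether to a benzyl-substituted triazole. Compound 1 `Fc1ccc(Cn2cc(CSC(=S)N3CCNCC3)nn2)cc1` carries a para-fluorophenyl group. In a functional assay on PC-3 cells (Homo sapiens) for inhibition, read by MTT assay, with a stated time of 72 h (on this read-out higher numbers stand for weaker inhibition and lower numbers for stronger inhibition), compound 1 gives only a limit, > 128000 nM. Compound 2 `S=C(SCc1cn(Cc2ccccc2Cl)nn1)N1CCNCC1` carries a 2-chlorophenyl group instead, and in this assay compound 2 has no result, "not determined" (no result reported). Among the compounds with values here, compound 2 therefore stands on no number at all; the one further value shown is the limit described by the limit of > 128000 nM in this assay, at which 1 of the 2 values shown sits. Compound 3 `Fc1ccccc1Cn1cc(CSC(=S)N2CCNCC2)nn1` differs from compound 2 by fluoro in place of chloro on an aromatic carbon. Within the data shown here, since compound 2 lacks a number, no size or direction of step in this assay can be anchored; the only guide is compound 1. Compound 3 is expected to show weak inhibition, with an estimated value near 150000 nM and a range from 40000 nM to 500000 nM.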

Compound 3, half-maximal inhibitory concentration: 56200 nM
Estimate against measurement, compound 3: 2.7-fold (0.43 log units) above; the range from low to high includes it.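

In this assay, within the data shown here, compound 3 gives the only measured number among the three compounds, so this benzyl ring can carry a group that brings inhibition within the range of the assay. On these data alone, changing 4-fluorophenyl to 2-fluorophenyl gives an at least 2.2-fold lower number from compound 1 to compound 3 (0.35 log units; beyond the scatter), which shows that the place of the fluoro on the ring matters here, although the full size of the step stays unknown: the limit of > 128000 nM in this assay, at which 1 of the 3 values shown sits. Compound 2 has no result, and the step from chloro to fluoro cannot be read.

The compounds shown leave open whether compound 2 would stand nearer compound 1 or compound 3. They also leave open how a methoxy group or an amine in place of the fluoro in compound 3 would read in this assay.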